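Fluoro in Place of Hexyl: What Compound 4 Might Show

The source may report more compounds than this note shows. Statements on the series, on what has been measured and on what is new or still open speak of the compounds shown alone.

Compound 1 `CCCCCc1ccc(NC(=O)N[C@@H](C)c2ccccc2)cc1`: 98%
Compound 2 `CCCCCCc1ccc(NC(=O)N[C@H](C)c2ccccc2)cc1`: 100%
Compound 3 `CCCCCCc1ccc(NC(=O)N[C@@H](C)c2ccccc2)cc1`: 99%

In an ADME assay on the whole organism with Oryza sativa as the target, tested at 0.1 uM (on this read-out higher numbers stand for a weaker effect at the one concentration tested and lower numbers for a stronger effect), compound 3 stands second highest of the three, with compound 1 nearest and compound 2 furthest, both within the scatter. The two measured steps, a number 1 percentage points higher from compound 1 to compound 3 (within the scatter) and a number 1 percentage points lower from compound 2 to compound 3 (within the scatter), are small; the second rests on (the fact that compounds 2 and 3 differ only in the configuration as drawn). Compound 4 `C[C@H](NC(=O)Nc1ccc(F)cc1)c1ccccc1` differs from compound 3 by fluoro in place of hexyl on an aromatic carbon. Neither measured step touches the group on the aromatic ring, so they give no direct guide to this change. With all three values close together, compound 4 is expected to show a number 3 percentage points lower from compound 3 to compound 4 (within the scatter), a step of unclear direction. The estimate for compound 4 is 96%, in the range 80% to 104%.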

Compound 4, a percentage reported as activity, at one concentration (the size of the read-out at that concentration, not a potency): 96%
Estimate against measurement, compound 4: no gap at the digits printed; the range from low to high includes it.
By their numbers in this assay, from the lowest: compounds 4, 1, 3 and 2 (each within the scatter of the next).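

In this assay the chain on this aromatic carbon gives way to a single fluorine atom with the read-out staying within the scatter (a number 3 percentage points lower from compound 3 to compound 4 (within the scatter)), and the same holds when fluoro replaces pentyl (a number 2 percentage points lower from compound 1 to compound 4 (within the scatter)). Among these compounds, the earlier compounds varied only chain length and configuration, so this is the first view of a group other than a chain at this place. Nothing available explains why the read-out holds here.

From the compounds shown here alone, whether an amine or a carboxylic acid on this aromatic carbon would move the number beyond the scatter stays open. So does the effect of a group other than fluoro or a chain at this place.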